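Cytotoxicity notes: trifluoromethyl removal on the benzyl amide

The compounds below may be only part of what the source reports. "The series", "measured", "known", "first", "only" and "open" are said of these compounds alone.

Measured so far:
- compound 1 `N[C@H]1CC[C@H](Nc2c(C(=O)NCc3cccc(C(F)(F)F)c3)nc(Br)c3cccnc23)CC1`: 4200 nM
- compound 2 `CS(=O)(=O)NCCCCCCN(c1nc(C(=O)NCc2ccc(F)cc2)c(O)c2ncccc12)S(C)(=O)=O`: 20000 nM

In a functional assay on MDA-MB-435 cells (Homo sapiens) for cytotoxicity, read by MTT assay, with a stated time of 72 h (on this read-out lower numbers stand for stronger inhibition and higher numbers for weaker inhibition), compound 1 gives 4200 nM, the lower of the two numbers. Compound 2 gives 20000 nM, a higher number that lies beyond the scatter. For the measured compounds named here, the two structures differ in many places, so no single step connects them.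

Compound 3 `N[C@H]1CC[C@H](Nc2c(C(=O)NCc3ccccc3)nc(Br)c3cccnc23)CC1` differs from compound 1 in one place: hydrogen in place of trifluoromethyl on an aromatic carbon. Going by the values given here, no measured pair shows this change, so the expected size is uncertain. The step of a 2.1-fold higher number from compound 1 to compound 3 (0.33 log units; beyond the scatter) is expected to be a modest weakening, probably just beyond the scatter. Compound 3 is estimated at 9000 nM, in the range 3000 nM to 25000 nM.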

Compound 3, half-maximal inhibitory concentration: 7000 nM
Beside the measured number, compound 3's estimate is 1.3-fold (0.11 log units) above it; the range from low to high includes it.
By their numbers in this assay, from the lowest: compounds 1 and 3 (each within the scatter of the next); then compound 2.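

In this assay hydrogen in place of trifluoromethyl gives a 1.7-fold higher number from compound 1 to compound 3 (0.22 log units; within the scatter) and so does not separate the two compounds. At this place on the benzyl amide, the trifluoromethyl group is therefore not needed to hold the number within the scatter, at least on this core with its bromine and aminocyclohexyl amine. No measurement on hand gives a reason for this result.

Open, as far as these compounds go, is whether a methoxy group, an amine or a carboxylic acid at this place would shift the number beyond the scatter. Also open, from the compounds shown here alone, is whether the same change stays this small on a different core.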